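The source may report more compounds than this note shows. Statements on the series, on what has been measured and on what is new or still open speak of the compounds shown alone.

Of the compounds shown here, three built on one shared core have been tested in a functional assay on the whole organism (strain Swiss) with Mus musculus as the target, in the maximal electroshock model, with a stated time of 2 h, at a dose of 300 mg/kg by the intraperitoneal route; a higher number here means a stronger effect of the compound at the dose given, a lower number a weaker effect. Compound 1 `CCC(C(=O)N1CCN(c2cccc(F)c2)CC1)N1C(=O)CCC1=O` gives 0% in this assay. Compound 2 `CCC(C(=O)N1CCN(c2ccccc2F)CC1)N1C(=O)CCC1=O` gives 0%, so that no change at the digits printed from compound 1 to compound 2 (within the scatter). Compound 3 `CCC(C(=O)N1CCN(c2cccc(C(F)(F)F)c2)CC1)N1C(=O)CCC1=O` gives 50%, the highest of the three numbers, and a number 50 percentage points higher from compound 1 to compound 3 (beyond the scatter), a large step that sets compound 3 clearly above both compound 1 and compound 2.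

Compound 4 `CCC(C(=O)N1CCN(c2cccc(C)c2)CC1)N1C(=O)CCC1=O` has not yet been measured. Its difference from compound 3 is methyl in place of trifluoromethyl on an aromatic carbon. Among the compounds with values here, only one measured step touches this place on the ring: the step from compound 1 to compound 3, in which fluoro became trifluoromethyl and the number rose strongly. Within the data shown here, no measured pair shows what a methyl does there, so its effect is open. Since the one large gain seen so far came with trifluoromethyl, removing it is expected to cost part of that gain, and compound 4 is estimated at 25%, within 0% to 60%, meaning an expected step of a number 25 percentage points lower from compound 3 to compound 4 (beyond the scatter).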

Compound 4, a percentage reported as activity, at one dose (the size of the read-out at that dose, not a potency): 0%
For compound 4 the middle estimate is 25 percentage points above the measured one; measured number inside the range.
By their numbers in this assay, from the lowest: compounds 1, 2 and 4 (each within the scatter of the next); then compound 3.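

Methyl in place of trifluoromethyl on this aromatic carbon gives a number 50 percentage points lower from compound 3 to compound 4 (beyond the scatter) in this assay at the single dose tested, so a single carbon attached at this place does not by itself carry the effect. Methyl also sits level with fluoro, with no change at the digits printed from compound 1 to compound 4 (within the scatter) for that exchange at the same place and no change at the digits printed from compound 2 to compound 4 (within the scatter) for 3-methylphenyl in place of 2-fluorophenyl. Among these four compounds, trifluoromethyl alone lifts the reading, while methyl, 3-fluorophenyl and 2-fluorophenyl all share the same value.

No measurement shown explains why trifluoromethyl stands apart. Open too, as far as these compounds go, are what a chlorine atom, a methoxy group or a nitrile would do at this place, and how strong the effect of compound 3 would be at any other dose.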